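A few compounds are considered here, and "the series" means these few. Any claim that something is new, unique, unknown or untested is made for them only; others in the source may bear on it.

Series of ureas on a shared core, read in an ADME assay on Raji cells (Homo sapiens) for cytotoxicity, with a stated time of 72 h; on this read-out lower numbers stand for an effect already at smaller amounts and higher numbers for an effect only at larger amounts of compound. Compound 1 `Cc1cc(NC(=O)Nc2ccc(N(C)C)cc2)c2ccccc2n1` gives > 25000 nM, which is a limit of the assay and not a number. Among the measured compounds shown here, compound 2 `Cc1cc(NC(=O)Nc2ccc(C(F)(F)F)cc2)c2ccccc2n1` gives 23000 nM, the only true number so far, so it has no measured neighbour to be ranked against. The limit also frames the reading: the limit of > 25000 nM in this assay, at which 1 of the 2 values shown sits.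

Next is compound 3 `Cc1cc(NC(=O)Nc2ccc(O)cc2)c2ccccc2n1`, which carries hydroxy in place of trifluoromethyl on an aromatic carbon, para to a large group: hydroxy in place of trifluoromethyl on an aromatic carbon. For the measured compounds named here, one measured step bears on this change, since it also swaps the group on an aromatic carbon of the same series. That step, trifluoromethyl in place of dimethylamino, is an at least 1.0-fold lower number from compound 1 to compound 2 (0.03 log units; that floor lies within the scatter). It is a floor within the scatter, so it shows no sizeable response to the exchange of this group, though one step is thin evidence. No step beyond the scatter is expected here, and the estimated change is a 1.0-fold lower number from compound 2 to compound 3 (0.02 log units; within the scatter). For compound 3 the expected value is 22000 nM, with an estimated range of 9000 nM to 50000 nM.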

Compound 3, half-maximal effective concentration: > 25000 nM
Compound 3: only a limit was reported; the forecaster's own chance of this, stated with the estimate: 55%; middle value at least 1.1-fold (0.05 log units) away from the limit.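

In this assay compound 3 gives > 25000 nM, which is a limit of the assay and not a number, so a much smaller group at this position, on an aromatic carbon para to a large group, also yields no true number. The exchange of trifluoromethyl for hydroxy, which brings in a hydrogen-bond donor and acceptor, is an at least 1.0-fold higher number from compound 2 to compound 3 (0.03 log units; that floor lies within the scatter); only this floor can be read, so no sizeable response is shown, though the true size of the step remains unknown. The step between compound 1 and compound 3 cannot be read, as both values are limits, and the top of the tested range now bounds most of the series: the limit of > 25000 nM in this assay, at which 2 of the 3 values shown sit.

Still open, on these data alone, is whether any group at this position can bring the read-out to a true number clearly lower than that of compound 2, which a carboxylic acid, a primary amine or a longer chain such as butoxy would test. Also open, as far as these compounds go, is whether the read-out responds to changes elsewhere on the shared core, such as replacing the methyl group with an ethyl group or a primary amine.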